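Triazole substituent series: from cyanobenzyl to tert-butylbenzyl

The source may report more compounds than this note shows. Statements on the series, on what has been measured and on what is new or still open speak of the compounds shown alone.

Compound 1 `CC(C)n1ncc2c(C(=O)NCc3cn(-c4ccccc4)nn3)cccc21`: > 40000 nM
Compound 2 `CC(C)n1ncc2c(C(=O)NCc3cn(Cc4ccccc4)nn3)cccc21`: 13700 nM
Compound 3 `CC(C)n1ncc2c(C(=O)NCc3cn(Cc4ccc(C#N)cc4)nn3)cccc21`: > 40000 nM

In a functional assay on HepG2 cells (Homo sapiens) for inhibition, read by MTT assay, with a stated time of 72 h (a higher number here means a weaker inhibitor, a lower number a stronger inhibitor), compound 1 gives only a limit, > 40000 nM. Compound 2 gives a number in this assay, 13700 nM. Compound 3 again gives only a limit in this assay, > 40000 nM. Compound 3 thus sits at the weak end of the three numbers shown, sharing the limit of > 40000 nM in this assay, at which 2 of the 3 values shown sit, with compound 1; compound 2 is the only one with a read number. The measured step of an at least 2.9-fold higher number from compound 2 to compound 3 (0.46 log units; beyond the scatter) shows the cyano substituent raising the number, while an at least 2.9-fold lower number from compound 1 to compound 2 (0.46 log units; beyond the scatter) shows the benzyl lowering it.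

Compound 4 `CC(C)n1ncc2c(C(=O)NCc3cn(Cc4ccc(C(C)(C)C)cc4)nn3)cccc21` carries the change (tert-butyl in place of cyano on an aromatic carbon). Going by the values given here, no measured step covers a tert-butyl group; the only bearing comes from the cyano leaving, the group whose entry gave an at least 2.9-fold higher number from compound 2 to compound 3 (0.46 log units; beyond the scatter). Compound 4 is therefore expected to land near 20000 nM, within a range from 7000 nM to 45000 nM. The expected step of an at least 2.0-fold lower number from compound 3 to compound 4 (0.30 log units; that floor lies within the scatter) is a lowering, though a limit remains possible.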

Compound 4, half-maximal inhibitory concentration: > 40000 nM
Compound 4: no number, only a limit; the forecaster's own chance of this, stated with the estimate: 40%; middle value at least 2.0-fold (0.30 log units) from the limit.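

In this assay, tert-butyl para to a large group gives an at least 2.9-fold higher number from compound 2 to compound 4 (0.46 log units; beyond the scatter), so a raised number at this position now goes with two different groups, not only with the nitrile of compound 3. The steps between two limits cannot be read, so cyano and tert-butyl cannot be ordered against each other. Going by these compounds alone, compound 2 remains the only compound with a read number, and every other value is a limit: the limit of > 40000 nM in this assay, at which 3 of the 4 values shown sit.

On these data alone, it remains open whether any group at this position keeps or lowers the number of compound 2, for example fluoro, methoxy or an amine. As far as these compounds go, it is also open whether a longer chain in place of the benzyl changes the number of compound 2.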